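The source may report more compounds than this note shows. Statements on the series, on what has been measured and on what is new or still open speak of the compounds shown alone.

In a functional assay on MCF7 cells (Homo sapiens) for inhibition, read by CCK-8 assay, with a stated time of 48 h (on this read-out higher numbers stand for weaker inhibition and lower numbers for stronger inhibition), compound 1 (`COc1cc(-c2ccnc3cc(-c4ccc(C)c(C)c4)nn23)cc(OC)c1OC`) gives 26 nM and compound 2 (`COc1cc(-c2ccnc3cc(-c4ccc(N(C)C)cc4)nn23)cc(OC)c1OC`) gives 44 nM, so compound 2 stands within the scatter of compound 1. Compound 3 (`COc1cc(-c2ccnc3cc(-c4ccc5ccn(C)c5c4)nn23)cc(OC)c1OC`) carries 1-methyl-1H-indol-6-yl in place of 4-(dimethylamino)phenyl on an aromatic carbon. Among the measured compounds shown here, the only measured step at this place, a 1.7-fold higher number from compound 1 to compound 2 (0.23 log units; within the scatter), lies within the scatter, and it involves no five-membered aromatic ring, so it is a limited guide. The step expected in this assay is a 1.3-fold lower number from compound 2 to compound 3 (0.10 log units; within the scatter), with none expected beyond the scatter. Compound 3 is estimated at 35 nM, with an expected range of 10 nM to 120 nM.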

Compound 3, half-maximal inhibitory concentration: 74 nM
For compound 3 the middle estimate is 2.1-fold (0.33 log units) below the measured one, within the range that was stated.
By their numbers in this assay, from the lowest: compounds 1, 2 and 3 (each within the scatter of the next, the first and the last beyond it).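

In this assay the change to 1-methyl-1H-indol-6-yl gives a 1.7-fold higher number from compound 2 to compound 3 (0.23 log units; within the scatter) against 4-(dimethylamino)phenyl and a 2.8-fold higher number from compound 1 to compound 3 (0.45 log units; beyond the scatter) against 3,4-dimethylphenyl. Among the compounds shown here, this is the first step at this place that lies beyond the scatter, and it comes with the first group here that holds a five-membered aromatic ring. No available evidence explains the difference.

Still open, as far as these compounds go, is how an aryl group carrying a primary amine or a carboxylic acid would read at this place. Also open, from the compounds shown here alone, is whether changes elsewhere on the shared core would move the number.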